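The source may report more compounds than this note shows. Statements on the series, on what has been measured and on what is new or still open speak of the compounds shown alone.

In an ADME assay on Vero cells (Chlorocebus sabaeus) for cytotoxicity, read by MTT assay, with a stated time of 72 h (a higher number here means a weaker inhibitor, a lower number a stronger inhibitor), compound 1 (`CC(=O)c1c(C)[n+]([O-])c2cc(-n3ccnc3)c(F)cc2[n+]1[O-]`) gives 95700 nM and compound 2 (`CCOC(=O)c1c(C)[n+]([O-])c2cc(-n3ccnc3)c(F)cc2[n+]1[O-]`) gives 129000 nM so these two sit together at the top of the three numbers in hand, within the scatter of each other. Among the measured compounds shown here, compound 3 (`CCOC(=O)c1c(C(F)(F)F)[n+]([O-])c2cc(-n3ccnc3)c(F)cc2[n+]1[O-]`) gives 19400 nM as the one value clearly lower than compound 2. Compound 4 (`Cc1c(C(=O)OC(C)C)[n+]([O-])c2cc(F)c(-n3ccnc3)cc2[n+]1[O-]`) has yet to be measured, and it departs from compound 2 by a single change: methyl in place of hydrogen on a saturated chain carbon bound to an oxygen next to a carbonyl group and a saturated chain carbon which reads as ethoxycarbonyl to isopropoxycarbonyl. For the measured compounds named here, two measured steps bear on this. The nearer is ethoxy in place of methyl on a carbonyl carbon, seen as a 1.3-fold higher number from compound 1 to compound 2 (0.13 log units; within the scatter) so a change on that same carbonyl left the number within the scatter. The other is trifluoromethyl in place of methyl on an aromatic carbon, seen as a 6.6-fold lower number from compound 2 to compound 3 (0.82 log units; beyond the scatter) but that is a modest step on an aromatic carbon, not on the chain that changes in compound 4, and it carries little weight here. For compound 4 the expected step is a 1.2-fold lower number from compound 2 to compound 4 (0.07 log units; within the scatter) and so none beyond the scatter. Compound 4 is therefore expected at 110000 nM with an estimated range from 50000 nM to 230000 nM in this assay once it is measured.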

Compound 4, half-maximal inhibitory concentration: 113000 nM
Beside the measured number, compound 4's estimate is 1.0-fold (0.01 log units) below it; low and high end bracket the measured number.
By their numbers in this assay, from the lowest: compound 3; then compounds 1, 4 and 2 (each within the scatter of the next).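

In this assay, among the compounds shown here, going from ethoxycarbonyl to isopropoxycarbonyl gives a 1.1-fold lower number from compound 2 to compound 4 (0.06 log units; within the scatter), so adding a methyl on the saturated chain carbon bound to the oxygen leaves the number unmoved within the scatter, something the earlier compounds could not show because none of them altered that chain. Against the methyl group of compound 1, the isopropoxy group gives a 1.2-fold higher number from compound 1 to compound 4 (0.07 log units; within the scatter), so methyl, ethoxy and isopropoxy on the carbonyl carbon now all lie within the scatter of one another, while the only step beyond the scatter remains a 6.6-fold lower number from compound 2 to compound 3 (0.82 log units; beyond the scatter) on an aromatic carbon. No measurement is at hand that would account for this flat response on the carbonyl carbon, and it stands here as an observation only.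

From the compounds shown here alone, whether the number would hold with a carboxylic acid, an amide or a longer chain such as butoxy on that carbonyl carbon stays open. Also open, going by these compounds, is whether trifluoromethyl on the aromatic carbon would give a step of similar size when paired with isopropoxycarbonyl instead of ethoxycarbonyl.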